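Adding a Second Trifluoromethyl Group to Compound 2

This account rests on a few compounds, and the source may have more. Where it says the series, first, only, none or still open, it means among the compounds named here.

In a functional assay on MCF7 cells (Homo sapiens) for cytotoxicity, read by MTT assay (on this read-out lower numbers stand for stronger inhibition and higher numbers for weaker inhibition), compound 1 (`Oc1ccc(CN(Cc2ccccc2C(F)(F)F)Cc2ccc(O)c3ncccc23)c2cccnc12`) gives 88 nM, while compound 2 (`Oc1ccc(CN(Cc2cccc(C(F)(F)F)c2)Cc2ccc(O)c3ncccc23)c2cccnc12`) gives 30 nM. Within the data shown here, compound 2 therefore holds the lower of the two numbers so far. Compound 3 (`Oc1ccc(CN(Cc2cc(C(F)(F)F)cc(C(F)(F)F)c2)Cc2ccc(O)c3ncccc23)c2cccnc12`) departs from compound 2 in one place, with trifluoromethyl in place of hydrogen on an aromatic carbon, meta to a trifluoromethyl group: trifluoromethyl in place of hydrogen on an aromatic carbon.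

Among the measured compounds shown here, only one measured step bears on this change. The step of a 2.9-fold lower number from compound 1 to compound 2 (0.47 log units; beyond the scatter) is modest but beyond the scatter, and it shows that this assay responds to where the trifluoromethyl group sits on its ring. For the measured compounds named here, that step relocates the group rather than adding a second one, so it is only a loose guide, and no measured pair shows the effect of an addition. A small change with a weak lean towards a lower number is therefore expected, and the expected step is a 1.2-fold lower number from compound 2 to compound 3 (0.08 log units; within the scatter). The direction remains uncertain. For compound 3 the estimated value is 25 nM, with an expected range from 9 nM to 70 nM.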

Compound 3, half-maximal inhibitory concentration: 38 nM
Estimate against measurement, compound 3: 1.5-fold (0.18 log units) below, and the stated range covers the measured number.
By their numbers in this assay, from the lowest: compounds 2 and 3 (each within the scatter of the next); then compound 1.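

In this assay, placing a second trifluoromethyl group on an aromatic carbon, meta to a trifluoromethyl group, gives a 1.3-fold higher number from compound 2 to compound 3 (0.10 log units; within the scatter), so compound 2 and compound 3 cannot be told apart on this read-out. The earlier compounds shown here showed only that moving a single trifluoromethyl group can matter, with a 2.9-fold lower number from compound 1 to compound 2 (0.47 log units; beyond the scatter) lying beyond the scatter; this result adds that, on the ring of compound 2, this aromatic carbon can carry a group of 4 heavy atoms in place of hydrogen without a step beyond the scatter. Nothing measured here offers an explanation for this outcome.

The compounds shown leave open whether a different group on this same aromatic carbon, such as a nitrile, a methoxy group or a chlorine atom, would also stay within the scatter of compound 2. They also leave open whether a second trifluoromethyl group would give a similarly small step if added to the ring of compound 1, where the first trifluoromethyl group sits elsewhere.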